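The compounds below may be only part of what the source reports. "The series", "measured", "known", "first", "only" and "open" are said of these compounds alone.

Measured so far in a functional assay on K562 cells (Homo sapiens) for cytotoxicity, read by MTT assay; a lower number here means that less compound is tolerated, a higher number that more compound is tolerated:

Compound 1 `COC(=O)C(C)(O)[C@](O)(C[C@H](C)CCC/C(C)=C/CC/C(C)=C/CCc1ccoc1)C(=O)OC` gives 20 ug/mL.
Compound 3 `COC(=O)C(C)(O)[C@](O)(C[C@H](C)CC/C=C(/C)CC/C=C(/C)CCCc1ccoc1)C(=O)OC` gives 34 ug/mL.
Compound 2 `COC(=O)C(C)(O)[C@](O)(C[C@H](C)CC/C=C(/C)CC/C=C(/C)CCCC1=CCN(CC(=O)O)C1=O)C(=O)OC` reaches only > 100 ug/mL, which is a limit of the assay and not a number.

Compound 1 and compound 3 carry the same atoms joined differently; the difference between the two cores is not broken down here. In this assay the two sit within the scatter of each other, so no order is drawn between them.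

One structural change is made twice in the series. From compound 3 to compound 2 it is a group of 10 heavy atoms (6 carbon, 1 nitrogen, 3 oxygen; one five-membered non-aromatic ring with 1 hetero atom) in place of a group of 5 heavy atoms (4 carbon, 1 oxygen; one five-membered aromatic ring with 1 hetero atom), on a saturated chain carbon, three bonds along the chain from a double-bonded chain carbon. The step is an at least 2.9-fold higher number from compound 3 to compound 2 (0.46 log units; beyond the scatter), and its size is bounded by the limit of > 100 ug/mL in this assay, at which 1 of the 3 values shown sits.

Compound 4 `COC(=O)C(C)(O)[C@](O)(C[C@H](C)CCC/C(C)=C/CC/C(C)=C/CCC1=CCN(CC(=O)O)C1=O)C(=O)OC` is not yet measured. Against compound 1 it carries the same kind of change, (a group of 10 heavy atoms (6 carbon, 1 nitrogen, 3 oxygen; one five-membered non-aromatic ring with 1 hetero atom) in place of a group of 5 heavy atoms (4 carbon, 1 oxygen; one five-membered aromatic ring with 1 hetero atom), on a saturated chain carbon, two bonds along the chain from a double-bonded chain carbon); the place differs in that the saturated chain carbon lies two bonds along the chain from a double-bonded chain carbon rather than three.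

For compound 4 the expected step in this assay is a 5.0-fold higher number from compound 1 to compound 4 (0.70 log units; beyond the scatter), resting on compound 1 at 20 ug/mL and on the measured step of an at least 2.9-fold higher number from compound 3 to compound 2 (0.46 log units; beyond the scatter). Compound 4 is estimated at 100 ug/mL, between 40 ug/mL and 300 ug/mL, with a fair chance that only a limit is reported.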

Compound 4, concentration lethal to 50% of the cells: > 100 ug/mL
Compound 4 ended at the assay's limit; the forecaster's own chance of this, stated with the estimate: 55%; the middle value lies on the limit itself.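

In this assay, replacing furan-3-yl with the group bearing the five-membered non-aromatic ring gives an at least 5.0-fold higher number from compound 1 to compound 4 (0.69 log units; beyond the scatter), so the direction seen on the other core recurs on the core of compound 1. The two steps can be set side by side only with caution: the same change on two cores in this assay, an at least 2.9-fold higher number (0.46 log units; beyond the scatter) from compound 3 to compound 2 and an at least 5.0-fold higher number (0.69 log units; beyond the scatter) from compound 1 to compound 4; the limit leaves it open whether they differ Compound 4 gives > 100 ug/mL, which is a limit and not a number, so the true size of its step remains unknown and no claim can be made that the change has the same size on both cores, with part of the series sitting at that ceiling: the limit of > 100 ug/mL in this assay, at which 2 of the 4 values shown sit.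

The compounds shown leave open which part of the entering group goes with the higher number, since the ring and its carboxylic acid side chain always enter together; a methyl ester or a primary amide in place of the carboxylic acid would separate them. Also open, going by these compounds, is whether a phenyl ring in place of furan-3-yl would leave the number unchanged on either core.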